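Methyl on the Ring Carbon: Two Matched Pairs

The source may hold more compounds than are shown below. What is called first, only, known or untested is meant among the compounds shown, and "the series" means these compounds.

Measured compounds:
Compound 1, `CC(=O)N(C)CC#CCn1ccnc1`: > 100 mg/kg
Compound 2, `CC(=O)N(C)CC#CCn1cncc1C`: > 100 mg/kg
Compound 3, `CN1CCN(CC#CCn2ccnc2)C1=O`: > 100 mg/kg

The study examines three compounds in a functional assay on the whole organism for antagonist activity, with Mus musculus as the target; on this read-out higher numbers stand for an effect only at larger amounts of compound and lower numbers for an effect already at smaller amounts. In this assay compound 1 reaches only a limit, > 100 mg/kg. Compound 2, which carries methyl in place of hydrogen on an aromatic carbon, likewise reaches only a limit in this assay, > 100 mg/kg. The step between them, a step that the two limits leave unreadable from compound 1 to compound 2, cannot be read because the limit of > 100 mg/kg in this assay, at which 3 of the 3 values shown sit, holds for both of its ends. Compound 3 differs from compound 1 in its core; the difference between the two cores is not broken down here. In this assay compound 3 also reaches only a limit, > 100 mg/kg.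

Compound 4, `Cc1cncn1CC#CCN1CCN(C)C1=O`, is not yet measured. It stands to compound 3 as compound 2 stands to compound 1, carrying (methyl in place of hydrogen on an aromatic carbon). It is the same kind of change: the place is described for the first pair as next to the ring atom that bears a group of 9 heavy atoms, and for the second as next to the ring atom that bears a large group. The size of the earlier step is unreadable, so no number can be carried over. The expectation for compound 4 rests on (the limit of > 100 mg/kg in this assay, at which 3 of the 3 values shown sit), at which every measured value sits, and so the expected step is a step that the limit leaves unreadable from compound 3 to compound 4. Compound 4 is therefore estimated at 150 mg/kg, within 60 mg/kg and 400 mg/kg, and most likely reported again as a limit.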

Compound 4, dose for half-maximal effect: > 100 mg/kg
Compound 4: no number, only a limit; the forecaster's own chance of this, stated with the estimate: 85%; the middle value does not contradict the limit.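

In this assay compound 4 gives > 100 mg/kg as a limit and not a number. The step from compound 3 to compound 4 therefore cannot be read, because both ends rest on the same limit: the limit of > 100 mg/kg in this assay, at which 4 of the 4 values shown sit. The compounds shown leave open whether methyl in place of hydrogen on an aromatic carbon changes the dose needed in either matched pair, and at what dose, if any, compound 1, compound 2, compound 3 or compound 4 acts.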